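The source may hold more compounds than are shown below. What is called first, only, known or untested is meant among the compounds shown, and "the series" means these compounds.

Values in a functional assay on A2780 cells (Homo sapiens) for cytotoxicity, read by sulforhodamine B assay, with a stated time of 72 h; a lower number here means a stronger inhibitor, a higher number a weaker inhibitor:
Compound 1 `CC(C)n1cc(S(=O)(=O)c2ccc(CNC(=O)N3Cc4ccncc4C3)cc2)cn1`: 11 nM
Compound 2 `O=C(NCc1ccc(S(=O)(=O)C2CCC(F)(F)CC2)cc1)N1Cc2ccncc2C1`: 13 nM
Compound 3 `O=C(NCc1ccc(S(=O)(=O)C2CCOCC2)cc1)N1Cc2ccncc2C1`: 35 nM

Of these three, compound 3 has the highest number, and its gaps to the other two both lie beyond the scatter. Compound 4 `O=C(NCc1ccc(S(=O)(=O)N2CCC[C@@H](O)C2)cc1)N1Cc2ccncc2C1` keeps the shared core of compound 3 and differs only in the group on the sulfonyl sulfur: 3-hydroxypiperidin-1-yl in place of oxan-4-yl on a sulfonyl sulfur. Here, 3-hydroxypiperidin-1-yl takes the place of oxan-4-yl.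

All three measured steps concern this same place. The first, a 1.2-fold higher number from compound 1 to compound 2 (0.07 log units; within the scatter), stays within the scatter. The other two are modest: a 3.2-fold higher number from compound 1 to compound 3 (0.50 log units; beyond the scatter) and a 2.7-fold higher number from compound 2 to compound 3 (0.43 log units; beyond the scatter). Across these three compounds, then, exchanging the group on the sulfonyl sulfur has moved the number only modestly. None of them carries 3-hydroxypiperidin-1-yl, however, so the data fix the direction poorly. The expectation in this assay is therefore a step no larger than those modest ones, probably within the scatter, with a slight lean towards a higher number. The expected step is a 1.3-fold higher number from compound 3 to compound 4 (0.11 log units; within the scatter). For compound 4 the estimated value is 45 nM, with an expected range from 14 nM to 150 nM.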

Compound 4, half-maximal inhibitory concentration: 70 nM
For compound 4 the middle estimate is 1.6-fold (0.19 log units) below the measured one; low and high end bracket the measured number.
By their numbers in this assay, from the lowest: compounds 1 and 2 (each within the scatter of the next); then compounds 3 and 4 (each within the scatter of the next).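

In this assay, compound 4 places 3-hydroxypiperidin-1-yl on the sulfonyl sulfur, the only group among these compounds that brings a hydrogen-bond donor and a defined stereocentre, and a 2.0-fold higher number from compound 3 to compound 4 (0.30 log units; within the scatter) shows that this exchange for oxan-4-yl stays within the scatter. The same group lies clearly apart from the two groups at the low end of the series, with a 5.4-fold higher number from compound 2 to compound 4 (0.73 log units; beyond the scatter) and a 6.4-fold higher number from compound 1 to compound 4 (0.80 log units; beyond the scatter), both beyond the scatter, so the four compounds at this position form two pairs, compounds 1 and 2 at the lower numbers and compounds 3 and 4 at the higher. Nothing available for these compounds accounts for that separation.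

The compounds shown do not separate the contribution of the hydroxyl from that of the ring nitrogen on the sulfonyl sulfur, and they leave the opposite stereoisomer of compound 4 unaddressed. Piperidin-1-yl without the hydroxyl, or 3-aminopiperidin-1-yl, would be the direct comparisons for telling these contributions apart at this position.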